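The source may report more compounds than this note shows. Statements on the series, on what has been measured and on what is new or still open speak of the compounds shown alone.

In a functional assay on HCT-8 cells (Homo sapiens) for antiproliferative activity, read by MTT assay, with a stated time of 48 h (on this read-out lower numbers stand for stronger inhibition and higher numbers for weaker inhibition), compound 1 (`COc1ccc(C(=O)c2ccc3c(c2)C=CC(C)(C)O3)c(NC(=O)CBr)c1`) gives 3260 nM and compound 2 (`CCNCC(=O)Nc1cc(OC)ccc1C(=O)c1ccc2c(c1)C=CC(C)(C)O2`) gives 3990 nM. Among the compounds with values here, these are the only two numbers so far, and they lie within the usual scatter of each other, so compound 2 stands level with compound 1. Compound 3 (`COc1ccc(C(=O)c2ccc3c(c2)C=CC(C)(C)O3)c(NC(=O)CN(C)C)c1`) has the same atoms as compound 2, joined differently: dimethylamino in place of ethylamino on a saturated chain carbon bound to a carbonyl carbon. Put simply, dimethylamino sits in place of ethylamino on a saturated chain carbon bound to a carbonyl carbon. Within the data shown here, one measured step bears on this spot, the swap of bromo for ethylamino, which gave a 1.2-fold higher number from compound 1 to compound 2 (0.09 log units; within the scatter). Among the measured compounds shown here, it is a single step, and no measured compound yet carries dimethylamino, so the evidence is thin. Going by that step, no change beyond the scatter is expected in this assay. The expected step is a 1.1-fold lower number from compound 2 to compound 3 (0.03 log units; within the scatter). For compound 3 the estimated value is 3700 nM, with an expected range from 1700 nM to 8000 nM.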

Compound 3, half-maximal inhibitory concentration: 2420 nM
For compound 3 the middle estimate is 1.5-fold (0.18 log units) above the measured one, and the stated range covers the measured number.
By their numbers in this assay, from the lowest: compounds 3, 1 and 2 (each within the scatter of the next).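

Replacing ethylamino with dimethylamino on the saturated chain carbon bound to a carbonyl carbon removes the hydrogen-bond donor of this group, and in this assay the swap gives a 1.6-fold lower number from compound 2 to compound 3 (0.22 log units; within the scatter) and so no shift that can be told from the scatter. Replacing bromo with dimethylamino gives a 1.3-fold lower number from compound 1 to compound 3 (0.13 log units; within the scatter) and again no such shift, so compound 1, compound 2 and compound 3 stand level with three quite different groups at this place. No measurement is available that would explain why these groups read alike.

The compounds shown leave open whether a ring amine such as morpholine or a carboxylic acid at this place would stay level with them. They also leave open whether a longer chain between the carbonyl and the amine would move the number beyond the scatter.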